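Replacing Hydroxy with Methylsulfanyl on the Shared Core

The source may report more compounds than this note shows. Statements on the series, on what has been measured and on what is new or still open speak of the compounds shown alone.

Going by the values given here, compound 2 `Cc1nc2c(OCc3ccccc3)cccn2c1CO` stands highest of the two numbers measured so far in a functional assay on the whole organism (stomach) for inhibition, with Canis familiaris (Canis lupus familiaris) as the target, at a dose of 5 mg/kg by the intravenous route (on this read-out lower numbers stand for a weaker effect and higher numbers for a stronger effect at the one dose given), where compound 2 gives 80%; its only neighbour, compound 1 `CC(=O)c1c(C)nc2c(OCc3ccccc3)cccn12`, gives 9%. Compound 3 `CSCc1c(C)nc2c(OCc3ccccc3)cccn12` differs from compound 2 by methylsulfanyl in place of hydroxy on a saturated chain carbon bound to an aromatic carbon. Among the compounds with values here, the one measured step at this position, a number 71 percentage points higher from compound 1 to compound 2 (beyond the scatter), shows that the group on this chain carbon can move the read-out greatly. Within the data shown here, no measured step covers methylsulfanyl in place of hydroxy, so a sizeable downward change is expected for compound 3, a number 35 percentage points lower from compound 2 to compound 3 (beyond the scatter). Compound 3 is estimated at 45%, within 15% to 80%.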

Compound 3, a percentage reported as inhibition, in the whole organism at one dose (the size of the read-out at that dose, not a potency): 8%
Compound 3: the middle estimate sits 37 percentage points above what was measured, outside the stated range (below it).
By their numbers in this assay, from the lowest: compounds 3 and 1 (each within the scatter of the next); then compound 2.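

Exchanging the hydroxy on this chain carbon gives a number 72 percentage points lower from compound 2 to compound 3 (beyond the scatter) in this assay, so the high number does not survive even a change confined to that one group. (Methylsulfanyl)methyl in place of acetyl gives a number 1 percentage points lower from compound 1 to compound 3 (within the scatter) and thus leaves the two low numbers alike, with hydroxymethyl alone among these three groups carrying the high number. Nothing given here accounts for this loss.

As far as these compounds go, whether methoxy or an amine in place of hydroxy, or a longer chain carrying the hydroxy, would hold the high number stays open.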